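Series notes: fluorophenyl for isobutyl on the aminothiazole nitrogen

The compounds below may be only part of what the source reports. "The series", "measured", "known", "first", "only" and "open" are said of these compounds alone.

Three compounds of this series have numbers in a functional assay on HCT-116 cells (Homo sapiens) for inhibition, read by MTT assay, with a stated time of 72 h; on this read-out lower numbers stand for stronger inhibition and higher numbers for weaker inhibition. Compound 1 `CC(C)CCN(CCCCCCC(=O)NO)c1ncc(C(=O)NCc2cccnc2)s1` gives 12000 nM, compound 3 `CC(C)CCN(CCCCCCC(=O)NO)c1ncc(C(=O)NCCCn2ccnc2)s1` gives 30000 nM, and compound 2 `O=C(CCCCCCCN(Cc1ccc(F)cc1)c1ncc(C(=O)NCCCn2ccnc2)s1)NO` gives 63000 nM. Compound 3 holds the second highest of the three numbers: nearest to it is compound 2, furthest is compound 1. Among the compounds with values here, the only single-point step among them, a 2.5-fold higher number from compound 1 to compound 3 (0.40 log units; beyond the scatter), concerns the amide side of the core and not the position changed here.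

Compound 4 `O=C(CCCCCCN(Cc1ccc(F)cc1)c1ncc(C(=O)NCCCn2ccnc2)s1)NO` is not yet measured. It differs from compound 3 as 4-fluorophenyl in place of isobutyl on a saturated chain carbon bound to a nitrogen on an aromatic ring. Within the data shown here, no measured step touches this position, so the bearing of the change on this assay is not known from the series. Compound 2 carries the same 4-fluorophenyl group on the same nitrogen, with the same imidazolyl amide, yet also differs from compound 4 elsewhere in the molecule. Compound 2 gives 63000 nM, the highest number seen. On that basis compound 4 is expected to land near or somewhat above compound 3, with an estimated step of a 1.5-fold higher number from compound 3 to compound 4 (0.18 log units; within the scatter), and a wide range given the lack of a direct comparison. The estimate for compound 4 is 45000 nM, ranging from 15000 nM to 130000 nM.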

Compound 4, half-maximal inhibitory concentration: 9700 nM
The estimate for compound 4 lay 4.6-fold (0.67 log units) above the measured number; measured number below the stated range.
By their numbers in this assay, from the lowest: compounds 4 and 1 (each within the scatter of the next); then compound 3; then compound 2.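

In this assay, within the data shown here, the change from isobutyl to 4-fluorophenyl on a saturated chain carbon bound to a nitrogen on an aromatic ring gives a 3.1-fold lower number from compound 3 to compound 4 (0.49 log units; beyond the scatter), the first reading at this position, and it shows that the number responds to the change with the imidazolyl amide held constant. The 4-fluorophenyl group does not by itself bring the high number seen earlier: with that group and the amide held constant, hydroxycarbamoyl in place of (hydroxycarbamoyl)methyl on a saturated chain carbon, six bonds along the chain from a nitrogen on an aromatic ring, gives a 6.5-fold lower number from compound 2 to compound 4 (0.81 log units; beyond the scatter). Both steps lie beyond the scatter, so the group on this nitrogen and the hydroxycarbamoyl end of the chain each move the number on their own.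

Still open, on these data alone, is whether the ring or the fluorine carries the first step, which a plain benzyl or a cyclohexylmethyl group in the same place would separate, and whether that step holds with the pyridin-3-yl amide of compound 1. No measurement at hand accounts for either step.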